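Aryl swap on the amide: compound 3 to compound 4

The source may report more compounds than this note shows. Statements on the series, on what has been measured and on what is new or still open speak of the compounds shown alone.

In a functional assay on A549 cells (Homo sapiens) for inhibition, read by MTT assay, with a stated time of 72 h (on this read-out lower numbers stand for stronger inhibition and higher numbers for weaker inhibition), compound 3 `O=C(Nc1ccc(F)c(Br)c1)C1CCN(C/C=C/c2ccccc2)CC1` gives 11700 nM. Compound 1 `CCc1ccc(NC(=O)C2CCN(C/C=C/c3ccccc3)CC2)cc1` gives 19600 nM, and the gap is a 1.7-fold lower number from compound 1 to compound 3 (0.22 log units; within the scatter). Compound 2 `COc1cccc(NC(=O)C2CCN(C/C=C/c3ccccc3)CC2)c1` gives 50500 nM, and the gap is a 4.3-fold lower number from compound 2 to compound 3 (0.64 log units; beyond the scatter). Compound 3 therefore stands level with compound 1 and clearly under compound 2.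

Compound 4 `N#Cc1ccc(NC(=O)C2CCN(C/C=C/c3ccccc3)CC2)cc1` differs as follows: 4-cyanophenyl in place of 3-bromo-4-fluorophenyl on an amide-type nitrogen. The measured steps at this same place are those above and a 2.6-fold higher number from compound 1 to compound 2 (0.41 log units; beyond the scatter). All are modest or smaller, and none involves a nitrile. A modest rise is expected, a 2.1-fold higher number from compound 3 to compound 4 (0.33 log units; beyond the scatter). Compound 4 is estimated at 25000 nM, with an expected range of 10000 nM to 60000 nM.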

Compound 4, half-maximal inhibitory concentration: 40200 nM
The estimate for compound 4 lay 1.6-fold (0.21 log units) below the measured number; low and high end bracket the measured number.
By their numbers in this assay, from the lowest: compounds 3 and 1 (each within the scatter of the next); then compounds 4 and 2 (each within the scatter of the next).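

In this assay the step of a 3.4-fold higher number from compound 3 to compound 4 (0.54 log units; beyond the scatter) shows that 4-cyanophenyl on this amide-type nitrogen does not hold the level of 3-bromo-4-fluorophenyl. Cyano in place of ethyl on an aromatic carbon, the first change here confined to a single ring substituent, gives a 2.1-fold higher number from compound 1 to compound 4 (0.31 log units; beyond the scatter) and so also moves the number up, whereas a 1.3-fold lower number from compound 2 to compound 4 (0.10 log units; within the scatter) leaves 4-cyanophenyl level with 3-methoxyphenyl. No measured property bears on these steps.

Open, as far as these compounds go, is how an amine or a carboxylic acid on that aromatic carbon would compare with cyano and ethyl.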